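A fluorine swap repeated on a second core

A few compounds are considered here, and "the series" means these few. Any claim that something is new, unique, unknown or untested is made for them only; others in the source may bear on it.

Three close relatives of one scaffold have been tested for their ability to slow the growth of a breast-cancer cell line, and a fourth awaits its turn. Compound 1 `COC(=O)c1sc2cc(OC)ccc2c1C#Cc1ccc(F)cc1` carries a 4-fluorophenyl on a triple-bonded carbon; compound 2 `COC(=O)c1sc2cc(OC)ccc2c1C#Cc1ccccc1F` differs from it only in bearing a 2-fluorophenyl there, and compound 3 `COC(=O)c1sc2ccccc2c1C#Cc1ccccc1F` keeps the 2-fluorophenyl of compound 2 but lacks its methoxy. In a functional assay on MCF7 cells (Homo sapiens) for cytotoxicity, read by sulforhodamine B assay, with a stated time of 48 h (on this read-out higher numbers stand for weaker inhibition of growth and lower numbers for stronger inhibition of growth), compound 1 gives 12600 nM, compound 2 gives 11400 nM, and compound 3 gives 40900 nM.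

Two comparisons follow. The fluorophenyl swap, (4-fluorophenyl in place of 2-fluorophenyl on a triple-bonded carbon), leaves the result essentially unchanged: a 1.1-fold higher number from compound 2 to compound 1 (0.04 log units; within the scatter). Removing the methoxy, (hydrogen in place of methoxy on an aromatic carbon), costs more: a 3.6-fold higher number from compound 2 to compound 3 (0.55 log units; beyond the scatter).

Compound 4 `COC(=O)c1sc2ccccc2c1C#Cc1ccc(F)cc1` has not been measured. It stands to compound 3 as compound 1 stands to compound 2: 4-fluorophenyl in place of 2-fluorophenyl on a triple-bonded carbon. The place of the change is the same in both pairs, a triple-bonded carbon whose other neighbour is a triple-bonded carbon, while the two cores differ by the methoxy described above. Because the earlier swap gave only a 1.1-fold higher number from compound 2 to compound 1 (0.04 log units; within the scatter), the step is expected to be small, a 1.1-fold higher number from compound 3 to compound 4 (0.04 log units; within the scatter), and it rests on that single precedent. Compound 4 is therefore estimated at 45000 nM, most plausibly between 20000 nM and 100000 nM, a guess held loosely given how little supports it.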

Compound 4, concentration for 50% growth inhibition: 60600 nM
Estimate against measurement, compound 4: 1.3-fold (0.13 log units) below; low and high end bracket the measured number.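

On the core without the methoxy, the fluorine swap gives a 1.5-fold higher number from compound 3 to compound 4 (0.17 log units; within the scatter), so moving the fluorine makes no difference that can be told from scatter in this assay, and the two cores agree on this: the same change on two cores in this assay, a 1.1-fold higher number (0.04 log units; within the scatter) from compound 2 to compound 1 and a 1.5-fold higher number (0.17 log units; within the scatter) from compound 3 to compound 4, 1.3-fold (0.13 log units) apart, within the scatter of two such steps

Putting hydrogen in place of methoxy, this time with the 4-fluorophenyl present, gives a 4.8-fold higher number from compound 1 to compound 4 (0.68 log units; beyond the scatter), a modest loss of growth inhibition that repeats what was seen with the 2-fluorophenyl: the same change on two cores in this assay, a 3.6-fold higher number (0.55 log units; beyond the scatter) from compound 2 to compound 3 and a 4.8-fold higher number (0.68 log units; beyond the scatter) from compound 1 to compound 4, 1.3-fold (0.13 log units) apart, within the scatter of two such steps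

Within these four compounds, then, the two changes carry over from one core to the other, but this rests on only two pairs of steps in a single cell line, and it shows neither why they behave this way nor that they would do so on a more distant core.

Going by these compounds, it remains open whether a hydroxyl or an ethoxy in place of the methoxy would keep the stronger growth inhibition, and what a chlorine or a trifluoromethyl in place of the fluorine would do. The methyl ester, shared by all four compounds, is also untested ground here, so the effect of a carboxylic acid or an amide in its place cannot be told from these data.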